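Ring substituent steps on the shared core, cell growth

The source may report more compounds than this note shows. Statements on the series, on what has been measured and on what is new or still open speak of the compounds shown alone.

Measured so far in a functional assay on NCI-H460 cells (Homo sapiens) for cytotoxicity, read by sulforhodamine B assay; a higher number here means a weaker inhibitor of growth, a lower number a stronger inhibitor of growth:
Compound 1 `CC1=CC[C@@H]([C@@](C)(O)CCCC(C)(C)NC(=S)N/N=C\c2ccccc2)CC1`, a limit of the assay: > 100000 nM.
Compound 2 `COc1ccc(/C=N\NC(=S)NC(C)(C)CCC[C@](C)(O)[C@@H]2CC=C(C)CC2)cc1`, a limit of the assay: > 100000 nM.
Compound 3 `CC1=CC[C@@H]([C@@](C)(O)CCCC(C)(C)NC(=S)N/N=C\c2cccc([N+](=O)[O-])c2)CC1`: 68600 nM.

Compound 1 stands at the limit of > 100000 nM in this assay, at which 2 of the 3 values shown sit; only a limit is known for it, and compound 2 rests at the same limit. Methoxy in place of hydrogen on an aromatic carbon gives a step that the two limits leave unreadable from compound 1 to compound 2, so that change cannot be read. Nitro in place of hydrogen on an aromatic carbon gives an at least 1.4-fold lower number from compound 1 to compound 3 (0.16 log units; that floor lies within the scatter), and the parallel an at least 1.4-fold lower number from compound 2 to compound 3 (0.16 log units; that floor lies within the scatter) agrees; the floor of each lies within the scatter, so a change beyond the scatter is not established, only a value that left the limit.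

Compound 4 `CC1=CC[C@@H]([C@@](C)(O)CCCC(C)(C)NC(=S)N/N=C\c2cccc(Cl)c2)CC1` carries the change (chloro in place of hydrogen on an aromatic carbon). Among the measured compounds shown here, the step that bears on it is the one to compound 3, the single ring substituent here that produced a readable number. For compound 4 the expected step is an at least 1.2-fold lower number from compound 1 to compound 4 (0.09 log units; that floor lies within the scatter), in the same direction as an at least 1.4-fold lower number from compound 1 to compound 3 (0.16 log units; that floor lies within the scatter) and of comparable, small size, with a real chance that only a limit is returned. Compound 4 is estimated at 80000 nM, with a range from 40000 nM to 160000 nM.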

Compound 4, concentration for total growth inhibition: > 100000 nM
Compound 4: only a limit was reported (the forecaster's own chance of this, stated with the estimate: 50%); middle value at least 1.2-fold (0.09 log units) from the limit.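

Chloro in place of nitro at this ring place, meta to a large group, gives an at least 1.4-fold higher number from compound 3 to compound 4 (0.16 log units; that floor lies within the scatter) in this assay and so establishes no change beyond the scatter, only that chloro did not carry the value off the limit as nitro did. The steps from compound 1 and compound 2 to compound 4 cannot be read, since both ends of each are limits, so chloro adds no measurable size of change against hydrogen or against the 4-methoxyphenyl compound. Compound 3 therefore remains the only compound of the four with a number, which shows that a substituent at this place does not by itself yield a readable value, and most of the set now rests at one ceiling: the limit of > 100000 nM in this assay, at which 3 of the 4 values shown sit.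

Whether the readable value of compound 3 belongs to nitro specifically stays open, as the gap to chloro is not shown to exceed the scatter. Also open, as far as these compounds go, is how a nitrile, a carboxylic acid or an amine at this same ring place would read, and whether any of them would fall clearly clear of the limit.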